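Amine-substituent variation on the indane core

The source may report more compounds than this note shows. Statements on the series, on what has been measured and on what is new or still open speak of the compounds shown alone.

Measured so far:
compound 1 `CS(=O)(=O)NC1Cc2ccc(NC(=O)c3ccccc3-c3ccc(C(F)(F)F)cc3)cc2C1` — 60 nM
compound 2 `O=C(NC1Cc2ccc(NC(=O)c3ccccc3-c3ccc(C(F)(F)F)cc3)cc2C1)c1ccccc1` — 270 nM

In an assay for inhibition of apolipoprotein B-100 (Homo sapiens), tested at 100 nM (a higher number here means a weaker inhibitor, a lower number a stronger inhibitor), compound 2 stands highest of the two numbers; its nearest neighbour, compound 1, sits lower, the gap being a 4.5-fold higher number from compound 1 to compound 2 (0.65 log units; beyond the scatter). Going by the values given here, that single step, benzoyl in place of methylsulfonyl on an amine nitrogen, is the only change recorded on this nitrogen and is modest but beyond the scatter.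

Compound 3 `CN(C)C(=O)NC1Cc2ccc(NC(=O)c3ccccc3-c3ccc(C(F)(F)F)cc3)cc2C1` is not yet measured. It differs from compound 2 by dimethylamino in place of phenyl on a carbonyl carbon, that is benzoyl to dimethylcarbamoyl, benzamido to (dimethylcarbamoyl)amino. Among the compounds with values here, the one step that bears on it, a 4.5-fold higher number from compound 1 to compound 2 (0.65 log units; beyond the scatter), shows the number on this nitrogen is sensitive to what is attached there. Compound 3 carries neither the methylsulfonyl of compound 1 nor the benzoyl of compound 2, so the expected step in this assay is a lowering of modest size, placing compound 3 between the two measured numbers. The estimate for compound 3 is 130 nM, range 50 nM to 350 nM, a step of a 2.1-fold lower number from compound 2 to compound 3 (0.32 log units; beyond the scatter).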

Compound 3, half-maximal inhibitory concentration: 120 nM
For compound 3 the middle estimate is 1.1-fold (0.03 log units) above the measured one; measured number inside the range.
By their numbers in this assay, from the lowest: compounds 1 and 3 (each within the scatter of the next); then compound 2.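

The step on the carbonyl carbon, read in this assay (a 2.3-fold lower number from compound 2 to compound 3 (0.35 log units; beyond the scatter)), shows that this nitrogen can carry a carbonyl without the full cost seen for benzoyl: with the carbonyl kept, exchanging phenyl for dimethylamino gives a modest change beyond the scatter. That ties the difference between compound 2 and compound 3 to the group on the carbonyl carbon, not to the presence of a carbonyl alone. Dimethylcarbamoyl and methylsulfonyl on this nitrogen cannot be told apart (a 2.0-fold higher number from compound 1 to compound 3 (0.30 log units; within the scatter)), so compound 3 and compound 1 form a pair within the scatter, and nothing at hand explains either step.

Still open, as far as these compounds go, is whether the phenyl ring itself matters or any larger group on the carbonyl carbon would do the same, which a methyl, a cyclohexyl or a morpholine ring in that place would test. Also open, from the compounds shown here alone, are a longer chain on the sulfonyl, such as ethylsulfonyl or propylsulfonyl, and a free primary amine on this nitrogen.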